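The source may hold more compounds than are shown below. What is called first, only, known or untested is meant among the compounds shown, and "the series" means these compounds.

Compound 1 `Cc1nn(-c2ncnc3nc[nH]c23)c2c1C(c1ccc(OC(C)C)cc1)CC(=O)N2` is the reference point of the series. In a functional assay on HEK293 cells for agonist activity at G-protein coupled receptor 39 (Homo sapiens), read by scintillation proximity assay and inositol phosphate accumulation, with a stated time of 75 min, in the presence of a further agent that is not named here (on this read-out higher numbers stand for an effect only at larger amounts of compound and lower numbers for an effect already at smaller amounts), compound 1 gives 18 nM, the lowest of the three numbers in hand. Compound 2 `O=C1/C(=C/NCCCO)C(c2ccccc2)=NN1c1nc2ccccc2s1` gives 200 nM in this assay, and compound 3 `CC(C)(C)c1cc(C(=O)N/N=C/c2ccc(O)cc2O)[nH]n1` gives 240 nM in this assay; both gaps to compound 1 lie beyond the scatter, so compound 1 is the most potent of the measured set. Compound 4 `Cc1nn(-c2ncnc3nc[nH]c23)c2c1C(NC(=O)Cc1cccs1)CC(=O)N2` is the unmeasured analogue; the change is (((thiophen-2-yl)methyl)carbonyl)amino in place of 4-isopropoxyphenyl on a saturated ring carbon. Among the measured compounds shown here, no measured pair shows a change of this kind, so the size of the step is open. The step of a 17-fold higher number from compound 1 to compound 4 (1.22 log units; beyond the scatter) is expected to be a loss, beyond the scatter. Compound 4 is expected to give 300 nM in this assay, within a range of 60 nM to 2000 nM.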

Compound 4, half-maximal effective concentration: 3 nM
Compound 4: the middle estimate sits 100-fold (2.00 log units) above what was measured; measured number outside the range, below it.
By their numbers in this assay, from the lowest: compound 4; then compound 1; then compounds 2 and 3 (each within the scatter of the next).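

In this assay the change to (((thiophen-2-yl)methyl)carbonyl)amino on the saturated ring carbon gives a 6.0-fold lower number from compound 1 to compound 4 (0.78 log units; beyond the scatter) and so shows that the 4-isopropoxyphenyl group is not required at this position. The position accepts a group that brings an amide hydrogen and a five-membered aromatic ring and still gives the lowest number in the series. No available data account for this gain.

This single pair does not separate the contribution of the amide from that of the thiophene. From the compounds shown here alone, how a phenylacetyl amide or a simple amine on this carbon would read remains open.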